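Series notes: formyloxy to hydroxy

This account rests on a few compounds, and the source may have more. Where it says the series, first, only, none or still open, it means among the compounds named here.

Compound 3 `O=COC1(C(=O)Nc2ccc([N+](=O)[O-])cc2)CCCCC1` stands lowest of the three numbers in a functional assay on MCF7 cells (Homo sapiens) for inhibition, read by MTT assay, with a stated time of 72 h; on this read-out lower numbers stand for stronger inhibition and higher numbers for weaker inhibition: compound 3 gives 35.4 nM, compound 1 `Cc1ccccc1C(=O)OC1(C(=O)Nc2ccc([N+](=O)[O-])cc2)CCCCC1` gives 516 nM and compound 2 `O=C(OC1(C(=O)Nc2ccc([N+](=O)[O-])cc2)CCCCC1)c1ccccc1` gives 903 nM. The step of a 15-fold lower number from compound 1 to compound 3 (1.16 log units; beyond the scatter) and the step of a 26-fold lower number from compound 2 to compound 3 (1.41 log units; beyond the scatter) both run toward compound 3, whereas a 1.8-fold higher number from compound 1 to compound 2 (0.24 log units; within the scatter) shows nothing beyond the scatter.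

Compound 4 `O=C(Nc1ccc([N+](=O)[O-])cc1)C1(O)CCCCC1` continues in the same direction: hydrogen in place of formyl on an oxygen on a saturated carbon, so that the formyloxy group of compound 3 becomes a hydroxy group. Going by the values given here, no measured step removes the acyl group entirely; the expectation rests on the two steps that cut it back. Both a 15-fold lower number from compound 1 to compound 3 (1.16 log units; beyond the scatter) and a 26-fold lower number from compound 2 to compound 3 (1.41 log units; beyond the scatter) were large and downward, so a further downward step in this assay is expected, though a smaller one, as the group that leaves is itself small. The expected step is a 2.0-fold lower number from compound 3 to compound 4 (0.29 log units; within the scatter). Compound 4 is estimated at 18 nM, with a range from 5 nM to 70 nM.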

Compound 4, half-maximal inhibitory concentration: 664 nM
Compound 4: the middle estimate sits 37-fold (1.57 log units) below what was measured; measured number outside the range, above it.
By their numbers in this assay, from the lowest: compound 3; then compounds 1, 4 and 2 (each within the scatter of the next).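

In this assay, the oxygen on a saturated carbon shows no steady trend with the size of the acyl group: the formyl group of compound 3 stands apart, and replacing it with hydrogen gives a large step the other way (a 19-fold higher number from compound 3 to compound 4 (1.27 log units; beyond the scatter)). The hydroxy compound stays level with both larger esters (a 1.4-fold lower number from compound 2 to compound 4 (0.13 log units; within the scatter); a 1.3-fold higher number from compound 1 to compound 4 (0.11 log units; within the scatter)), so of the four compounds only the formyloxy compound separates, while hydrogen, benzoyl and (2-methylphenyl)carbonyl on this oxygen cannot be told apart. No measurement shown accounts for the separate standing of the formyloxy compound.

Whether the low number belongs to formyl alone remains open, as the compounds shown include no acetyl group or methyl ether on this oxygen. From the compounds shown here alone, how an amine in place of the hydroxy group would stand is also open.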